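The source may hold more compounds than are shown below. What is called first, only, known or untested is meant among the compounds shown, and "the series" means these compounds.

Measured compounds in a functional assay on MCF7 cells (Homo sapiens) for antiproliferative activity, read by sulforhodamine B assay, with a stated time of 48 h; on this read-out higher numbers stand for weaker inhibition and lower numbers for stronger inhibition:
compound 1, `CCc1ccccc1NS(=O)(=O)c1ccc(N2CCNC2=O)cc1`, gives 350 nM
compound 2, `Cc1ccc(NS(=O)(=O)c2ccc(N3CCNC3=O)cc2)cc1`, gives 610 nM
compound 3, `O=C1NCCN1c1ccc(S(=O)(=O)Nc2cccc(Br)c2)cc1`, gives 100 nM

Among these three numbers compound 2 carries the highest. The nearest to it is compound 1, where the step of a 1.7-fold higher number from compound 1 to compound 2 (0.24 log units; within the scatter) stays within the scatter, so the two are not told apart. The furthest is compound 3, reached by the step of a 6.1-fold lower number from compound 2 to compound 3 (0.79 log units; beyond the scatter), a modest drop in the number; the step of a 3.5-fold lower number from compound 1 to compound 3 (0.54 log units; beyond the scatter) points the same way.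

Compound 4, `CC(C)Cc1ccc(NS(=O)(=O)c2ccc(N3CCNC3=O)cc2)cc1`, differs from compound 2 by one change: isopropyl in place of hydrogen on a saturated chain carbon bound to an aromatic carbon. Among the measured compounds shown here, no measured pair mirrors this change, since each measured step swaps one whole aryl substituent for another rather than lengthening a chain. The closest hint is the step of a 1.7-fold higher number from compound 1 to compound 2 (0.24 log units; within the scatter), where two alkyl-bearing aryl groups sat within the scatter of each other, and the drop to compound 3 came with a bromine, not with an alkyl chain. On that basis compound 4 is expected to stay close to compound 2, with a step of a 1.1-fold lower number from compound 2 to compound 4 (0.04 log units; within the scatter) that may not clear the scatter. The estimate for compound 4 in this assay is 550 nM, within a range from 200 nM to 1500 nM.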

Compound 4, half-maximal inhibitory concentration: > 1000 nM
Compound 4: only a limit was reported; the forecaster's own chance of this, stated with the estimate: 5%; at least 1.8-fold (0.25 log units) between middle value and limit.
By their numbers in this assay, from the lowest: compound 3; then compounds 1 and 2 (each within the scatter of the next). At a limit, above all of these: compound 4.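

In this assay, compound 4 is reported only as a limit, not as a number: the limit of > 1000 nM in this assay, at which 1 of the 4 values shown sits. The step, an at least 1.6-fold higher number from compound 2 to compound 4 (0.21 log units; that floor lies within the scatter), has a floor within the scatter, so it does not establish that going from methyl to isobutyl raises the number. Among the compounds shown here, what it adds is the first view of a change on a saturated chain carbon bound to an aromatic carbon, as the earlier steps swapped whole aryl substituents, and here the larger isobutyl group brings no sign of a lower number.

As far as these compounds go, how far the true value of compound 4 lies past its limit stays open. So does how a chain ending in an amine or a carboxylic acid would read in this assay in place of isobutyl.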